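The source may hold more compounds than are shown below. What is called first, only, known or untested is meant among the compounds shown, and "the series" means these compounds.

Measured in a functional assay on HCT-116 cells (Homo sapiens) for antiproliferative activity, read by MTT assay, with a stated time of 72 h; on this read-out higher numbers stand for weaker inhibition and lower numbers for stronger inhibition:
Compound 1 `O=C(CCc1cccc2c1B(O)OC2)Nc1cccc(-c2ccc(F)cc2)c1`: 550 nM
Compound 2 `O=C(CCc1cccc2c1B(O)OC2)Nc1cccc(-c2cccc(C(F)(F)F)c2)c1`: 580 nM

For the measured compounds named here, only two numbers exist so far, and compound 2 cannot be told apart from its single neighbour: the one measured step is a 1.1-fold higher number from compound 1 to compound 2 (0.02 log units; within the scatter). Compound 3 `CC(=O)c1cccc(-c2cccc(NC(=O)CCc3cccc4c3B(O)OC4)c2)c1` has acetyl in place of trifluoromethyl on an aromatic carbon. The measured step also swapped a group on an aromatic carbon, though a different pair of groups, and it stayed small, so little movement is expected in this assay. The expected change is a 1.0-fold higher number from compound 2 to compound 3 (0.01 log units; within the scatter), with no direction favoured and nothing beyond the scatter. The estimate for compound 3 is 600 nM, with an expected range of 250 nM to 1500 nM.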

Compound 3, half-maximal inhibitory concentration: 86 nM
Beside the measured number, compound 3's estimate is 7.0-fold (0.84 log units) above it, outside the stated range (below it).
By their numbers in this assay, from the lowest: compound 3; then compounds 1 and 2 (each within the scatter of the next).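

In this assay the aromatic carbon meta to a large group proves sensitive to what it carries: acetyl in place of trifluoromethyl gives a 6.7-fold lower number from compound 2 to compound 3 (0.83 log units; beyond the scatter) while the earlier swap of groups stayed within the scatter. 3-Acetylphenyl in place of 4-fluorophenyl likewise gives a 6.4-fold lower number from compound 1 to compound 3 (0.81 log units; beyond the scatter) so the lower number holds against both earlier neighbours. Nothing available here accounts for this difference.

As far as these compounds go, it remains open whether the carbonyl of acetyl is what matters, or whether an amine or a carboxylic acid on this carbon would do the same. From the compounds shown here alone, whether a longer chain ending in a ketone keeps the lower number is also open.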